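Cytotoxicity of a benzamide series with varied ether side chains

The source may hold more compounds than are shown below. What is called first, only, known or untested is meant among the compounds shown, and "the series" means these compounds.

Measured so far in a toxicity assay on Huh-7.5 cells (Homo sapiens) for inhibition, read by MTT assay, with a stated time of 96 h; a lower number here means that less compound is tolerated, a higher number that more compound is tolerated:
- compound 1, `CCC(=O)Nc1cc(C(=O)Nc2ccc(OC)cc2)ccc1OC(C)C`: 113000 nM
- compound 2, `CCC(=O)Nc1cc(C(=O)Nc2ccc(OC)cc2)ccc1OCCCCl`: 158000 nM
- compound 3, `CCCOc1ccc(C(=O)Nc2ccc(OC)cc2)cc1NC(=O)CC`: 106000 nM

These three numbers sit in a narrow band, and compound 3 gives the lowest of them: a 1.1-fold lower number from compound 1 to compound 3 (0.03 log units; within the scatter) and a 1.5-fold lower number from compound 2 to compound 3 (0.17 log units; within the scatter). Compound 4, `CCC(=O)Nc1cc(C(=O)Nc2ccc(OC)cc2)ccc1OCCCN1CCN(C)CC1`, carries 4-methylpiperazin-1-yl in place of hydrogen on a saturated chain carbon, three bonds along the chain from an oxygen on an aromatic ring. Going by the values given here, the only step at that place is the chloro-to-hydrogen change, a 1.5-fold lower number from compound 2 to compound 3 (0.17 log units; within the scatter), and the ether swaps a 1.4-fold higher number from compound 1 to compound 2 (0.15 log units; within the scatter) and a 1.1-fold lower number from compound 1 to compound 3 (0.03 log units; within the scatter) also stayed within the scatter. Among the compounds with values here, no measured step covers a change of this kind, so compound 4 is expected to give about 90000 nM in this assay, with a range from 30000 nM to 250000 nM, an expected step of a 1.2-fold lower number from compound 3 to compound 4 (0.07 log units; within the scatter), that is, no step beyond the scatter.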

Compound 4, half-maximal cytotoxic concentration: 127000 nM
The estimate for compound 4 lay 1.4-fold (0.15 log units) below the measured number; low and high end bracket the measured number.
By their numbers in this assay, from the lowest: compounds 3, 1, 4 and 2 (each within the scatter of the next).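

In this assay, 4-methylpiperazin-1-yl on a saturated chain carbon, three bonds along the chain from an oxygen on an aromatic ring, gives a 1.2-fold higher number from compound 3 to compound 4 (0.08 log units; within the scatter), a 1.2-fold lower number from compound 2 to compound 4 (0.09 log units; within the scatter) and a 1.1-fold higher number from compound 1 to compound 4 (0.05 log units; within the scatter). This place therefore carries a group with a six-membered ring of its own without a step beyond the scatter, just as it carried hydrogen and chloro. No measurement here offers an explanation for this tolerance.

Going by these compounds, whether a morpholine, a carboxylic acid or a longer chain would also stay within the scatter remains open. What, if anything, would move this number beyond the scatter is equally unknown.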